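The source may report more compounds than this note shows. Statements on the series, on what has been measured and on what is new or still open speak of the compounds shown alone.

Among the compounds with values here, in a functional assay on A549 cells (Homo sapiens) for inhibition, read by CCK-8 assay, with a stated time of 48 h (a higher number here means a weaker inhibitor, a lower number a stronger inhibitor), compound 2 `COc1cc(-c2ccnc3cc(-c4ccc5cc[nH]c5c4)nn23)cc(OC)c1OC` gives 170 nM, the lower of the two numbers so far, and compound 1 `COc1cc(-c2ccnc3cc(-c4ccc(F)cc4)nn23)cc(OC)c1OC` gives 3800 nM. Within the data shown here, the one measured step, a 22-fold lower number from compound 1 to compound 2 (1.35 log units; beyond the scatter), replaced 4-fluorophenyl with 1H-indol-6-yl. Compound 3 `COc1cc(-c2ccnc3cc(-c4ccc(C(F)(F)F)cc4)nn23)cc(OC)c1OC` moves back from the indole to a substituted phenyl: 4-(trifluoromethyl)phenyl in place of 1H-indol-6-yl on an aromatic carbon. Its 4-(trifluoromethyl)phenyl group resembles the 4-fluorophenyl of compound 1, which stands at 3800 nM, so much of that earlier gain is expected to be lost in this assay. The expected change is large and toward a higher number: a 15-fold higher number from compound 2 to compound 3 (1.17 log units; beyond the scatter). For compound 3 the estimated value is 2500 nM, with an expected range of 700 nM to 9000 nM.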

Compound 3, half-maximal inhibitory concentration: 2070 nM
Estimate against measurement, compound 3: 1.2-fold (0.08 log units) above; the measured number falls inside the stated range.
By their numbers in this assay, from the lowest: compound 2; then compounds 3 and 1 (each within the scatter of the next).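

The change back to a substituted phenyl gives a 12-fold higher number from compound 2 to compound 3 (1.09 log units; beyond the scatter) in this assay and so shows that the gain at this aromatic carbon does not extend to every group tried: among these three compounds, it belongs to 1H-indol-6-yl alone. Trifluoromethyl in place of fluoro on the phenyl ring gives a 1.8-fold lower number from compound 1 to compound 3 (0.26 log units; within the scatter) and so does not separate these two compounds. Nothing available explains why the indole stands apart.

On these data alone, whether a phenyl ring carrying an amine or a hydroxyl group would approach the indole, or stay with compound 1 and compound 3, remains open.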